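The source may report more compounds than this note shows. Statements on the series, on what has been measured and on what is new or still open speak of the compounds shown alone.

In a functional assay on DU-145 cells (Homo sapiens) for antiproliferative activity, read by propidium iodide staining, with a stated time of 96 h (a lower number here means a stronger inhibitor, a higher number a weaker inhibitor), compound 1 `CC(O)(CSc1cccc(OC(F)(F)F)c1)C(=O)Nc1cccc(S(F)(F)(F)(F)F)c1` gives 25000 nM, compound 2 `CC(O)(COc1ccc(S(F)(F)(F)(F)F)cc1)C(=O)Nc1ccc(C#N)cc1C(F)(F)F` gives 16000 nM and compound 3 `CC(O)(COc1cccc(S(F)(F)(F)(F)F)c1)C(=O)Nc1ccc(S(F)(F)(F)(F)F)cc1` gives 29600 nM. Compound 3 therefore lies within the scatter of both other compounds, and the three values cannot be ranked.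

Compound 4 `CC(O)(COc1cccc(C(F)(F)F)c1)C(=O)Nc1ccc(S(F)(F)(F)(F)F)cc1` differs from compound 3 by a group of 4 heavy atoms (1 carbon, 3 fluorine; no ring) in place of a group of 6 heavy atoms (5 fluorine, 1 sulfur; no ring), on an aromatic carbon. Trifluoromethyl enters on an aromatic carbon of a six-membered aromatic ring of carbon only, meta to a large group, in place of a group with no common name.

Among the measured compounds shown here, no measured pair in this set differs in one place, so no single-change step is available as a guide. For the measured compounds named here, the only support is that compound 1 at 25000 nM, compound 2 at 16000 nM and compound 3 at 29600 nM stay within the scatter despite their differing structures. In this assay, no change beyond the scatter and no particular direction is expected. The expected step is a 1.3-fold lower number from compound 3 to compound 4 (0.13 log units; within the scatter). The estimated value for compound 4 is 22000 nM, with an expected range from 10000 nM to 45000 nM.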

Compound 4, half-maximal inhibitory concentration: 21900 nM
Compound 4: the middle estimate sits 1.0-fold (0.00 log units) above what was measured, within the range that was stated.
By their numbers in this assay, from the lowest: compounds 2, 4, 1 and 3 (each within the scatter of the next).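

In this assay the series gains its first single-change step: trifluoromethyl in place of the group of 6 heavy atoms (5 fluorine, 1 sulfur), on an aromatic carbon meta to a large group, gives a 1.4-fold lower number from compound 3 to compound 4 (0.13 log units; within the scatter) in this comparison. At this position, the two groups therefore cannot be told apart in this assay, despite their different heavy-atom counts. No available measurement bears on the reason for this result.

On these data alone, whether an amine or a carboxylic acid on the same aromatic carbon would give a step beyond the scatter remains open. Also open, as far as these compounds go, is whether the same exchange would give a comparable step on the core of compound 1, which has a sulfur atom where compound 4 has an oxygen atom.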